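Methoxyphenyl variation on the aromatic nitrogen

A few compounds are considered here, and "the series" means these few. Any claim that something is new, unique, unknown or untested is made for them only; others in the source may bear on it.

Measured so far:
compound 1, `COc1cccc(Nc2n[nH]c(-c3cccnc3Nc3cc(OC)cc(OC)c3)n2)c1`: 72%
compound 2, `COc1ccc(Nc2n[nH]c(-c3cccnc3Nc3cc(OC)cc(OC)c3)n2)cc1`: 68%

Both numbers come from a functional assay on A-431 cells (Homo sapiens), tested at 0.1 uM; a lower number here means less inhibition, a higher number more inhibition at the concentration tested (going by the name of the read-out). Compound 2 gives the lower of the two, but the step of a number 4 percentage points lower from compound 1 to compound 2 (within the scatter) lies within the scatter, so the two compounds cannot be told apart on this read-out.

The next compound, compound 3 `COc1cc(Nc2ncccc2-c2nc(Nc3cc(OC)ccc3OC)n[nH]2)cc(OC)c1`, is not yet measured. It differs from compound 2 in one place: 2,5-dimethoxyphenyl in place of 4-methoxyphenyl on a nitrogen on an aromatic ring.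

Among the compounds with values here, only one measured step exists, a number 4 percentage points lower from compound 1 to compound 2 (within the scatter), and it concerns the exchange of 3-methoxyphenyl for 4-methoxyphenyl on the same nitrogen. That exchange left the inhibition unchanged within the scatter. Within the data shown here, no measured pair shows the effect of a second methoxy group on that phenyl ring. The expectation for this assay therefore rests on that single step alone: the step expected is no change at the digits printed from compound 2 to compound 3 (within the scatter), none beyond the scatter. Compound 3 is estimated at 68%, with a range from 52% to 82%. Among the measured compounds shown here, no measured compound carries two methoxy groups on that ring, and the range is accordingly kept wide.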

Compound 3, a percentage reported as inhibition, at one concentration (the size of the read-out at that concentration, not a potency): 20%
Compound 3: middle estimate off by 48 percentage points, on the high side, and the stated range ends above it.
By their numbers in this assay, from the lowest: compound 3; then compounds 2 and 1 (each within the scatter of the next).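

Within the data shown here, until now, the substituted phenyl on this nitrogen looked indifferent, since moving the single methoxy left compounds 1 and 2 within the scatter of each other, but in this assay the 2,5-dimethoxyphenyl group gives a number 48 percentage points lower from compound 2 to compound 3 (beyond the scatter) and so shows that this position does respond to the substitution on that ring. Read as a single change, methoxy in place of hydrogen on an aromatic carbon gives a number 52 percentage points lower from compound 1 to compound 3 (beyond the scatter), which means that one added methoxy on the ring of compound 1, with the rest of the molecule unchanged, is enough for a large loss of inhibition at the concentration tested. Nothing available on these compounds bears on the reason for this loss.

Open, on these data alone, is whether the loss belongs to methoxy itself or to any group on that carbon, a question that a fluorine, a hydroxyl or an amine in its place would help to settle. Also open, as far as these compounds go, is how far these single-concentration numbers reflect potency, and whether the other methoxy on the ring of compound 3 can be exchanged, for instance for an ethoxy, without changing the result.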